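The source may hold more compounds than are shown below. What is called first, only, known or untested is meant among the compounds shown, and "the series" means these compounds.

Measured compounds:

- Compound 1 `C=C1C[C@]23C[C@@]1(O)CC[C@H]2c1ccc(O)c(C)c1[C@@H]3Cn1cc(-c2ccccn2)nn1`: in a functional assay on A549 cells (Homo sapiens) for cytotoxicity, read by MTT assay, with a stated time of 4 days (a higher number here means a weaker inhibitor, a lower number a stronger inhibitor), compound 1 gives > 20000 nM, which is a limit of the assay and not a number.
- Compound 2 `C=C1C[C@]23C[C@@]1(O)CC[C@H]2c1ccc(OS(=O)(=O)c2ccc(C)cc2)c(C)c1[C@@H]3Cn1cc(-c2ccc(Cl)cc2)nn1`: compound 2 gives > 20000 nM, again a limit of the assay.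
- Compound 3 `C=C1C(=O)[C@]23C[C@@]1(O)CC[C@H]2c1ccc(O)c(C)c1[C@@H]3Cn1cc(-c2ccc(Cl)cc2)nn1`: compound 3 gives 640 nM.

Compound 2 stands at the limit of this assay, with no number of its own; the same holds for compound 1, so that the limit of > 20000 nM in this assay, at which 2 of the 3 values shown sit, is where two of the three values shown sit. Among the compounds with values here, compound 3 is the only one of the three with a measured number, but it differs from compound 2 in more than one place, so no single step between them is counted and nothing beyond the two values themselves can be read from the pair.

Compound 4 `C=C1C[C@]23C[C@@]1(O)CC[C@H]2c1ccc(OS(=O)(=O)c2ccc(C)cc2)c(C)c1[C@@H]3Cn1cc(-c2ccc(C(F)(F)F)cc2)nn1` differs from compound 2 in one place: trifluoromethyl in place of chloro on an aromatic carbon. Within the data shown here, no measured step of this kind exists, so the size of the change is unknown from these data. Given that compound 2 sits at the limit, the step from a step that the limit leaves unreadable from compound 2 to compound 4 is expected to be none beyond the scatter, with the likeliest outcome that compound 4 also returns a limit. The estimate for compound 4 in this assay is 25000 nM, within a range of 8000 nM to 80000 nM.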

Compound 4, half-maximal inhibitory concentration: > 20000 nM
Compound 4 was reported as a limit; the forecaster's own chance of this, stated with the estimate: 70%; the middle value is on the limit's open side.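

In this assay compound 4 gives > 20000 nM, a limit of the assay and not a number. Compound 2 also stands at a limit, and no step can be read between compound 2 and compound 4: the limit of > 20000 nM in this assay, at which 3 of the 4 values shown sit.

From the compounds shown here alone, whether 4-chlorophenyl and 4-(trifluoromethyl)phenyl differ at all in this assay stays open.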